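Sulfone in place of piperidine on a chemokine receptor antagonist

The compounds below may be only part of what the source reports. "The series", "measured", "known", "first", "only" and "open" are said of these compounds alone.

Of the compounds shown here, three sharing one core have been tested in a functional assay on cells for antagonist activity at C-X-C chemokine receptor type 4 (Homo sapiens), read by fluorescence and calcium flux, with stated times of 25 min and 90 s; on this read-out lower numbers stand for stronger inhibition and higher numbers for weaker inhibition. Compound 1 `c1cncc(CN(CCCCN(C[C@H]2Cc3ccccc3CN2)[C@H]2CCCc3cccnc32)Cc2cccnc2)c1` gives 471 nM and compound 2 `c1ccc2c(c1)CN[C@@H](CN(CCCCN(Cc1ccncc1)Cc1ccncc1)[C@H]1CCCc3cccnc31)C2` gives 832 nM. Compound 3 `c1ccc2c(c1)CN[C@@H](CN(CCCCNCC1CCNCC1)[C@H]1CCCc3cccnc31)C2` gives 36.5 nM, the lowest of the three numbers; the other two lie above it beyond the usual scatter, so compound 3 is the strongest inhibitor measured. Compound 4 `O=S1(=O)CCC(NCCCCN(C[C@H]2Cc3ccccc3CN2)[C@H]2CCCc3cccnc32)CC1` has not been measured and differs from compound 3 in one place: 1,1-dioxothian-4-yl in place of (piperidin-4-yl)methyl on an amine nitrogen. Within the data shown here, no measured pair shows this exchange, so the expectation rests on compound 3 and its 36.5 nM. A moderate step toward a higher number, beyond the scatter, is expected, and the estimated change from compound 3 to compound 4 is a 5.5-fold higher number from compound 3 to compound 4 (0.74 log units; beyond the scatter). Compound 4 is therefore expected to give about 200 nM, within a range of 60 nM to 800 nM.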

Compound 4, half-maximal inhibitory concentration: 45.5 nM
For compound 4 the middle estimate is 4.4-fold (0.64 log units) above the measured one, and the stated range ends above it.
By their numbers in this assay, from the lowest: compounds 3 and 4 (each within the scatter of the next); then compounds 1 and 2 (each within the scatter of the next).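

In this assay, among these compounds, 1,1-dioxothian-4-yl in place of (piperidin-4-yl)methyl on an amine nitrogen gives a 1.2-fold higher number from compound 3 to compound 4 (0.10 log units; within the scatter), the first exchange here that can be read in one place. So the number holds when the entering group has 0 hydrogen-bond donors where the leaving group has 1, and the piperidine nitrogen is not required for it. Nothing measured here explains this result. Still open, as far as these compounds go, is how a plain cyclohexyl ring, a carboxylic acid or a longer chain would read on this amine nitrogen.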